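The source may report more compounds than this note shows. Statements on the series, on what has been measured and on what is new or still open speak of the compounds shown alone.

Among the compounds with values here, compound 2 `CC(C)(C)c1ccc(S(=O)(=O)Nc2ccc(Cl)cc2-c2ncncc2N)cc1` stands lowest of the two numbers so far in a functional assay on isolated protein for antagonist activity at C-C chemokine receptor type 9 (Homo sapiens), read by calcium flux, with a stated time of 10 min; on this read-out lower numbers stand for stronger inhibition and higher numbers for weaker inhibition: compound 2 gives 3.2 nM. Its nearest neighbour is compound 1 `CC(C)(C)c1ccc(S(=O)(=O)Nc2ccc(Cl)cc2-c2ncccc2CN)cc1`, which in this assay gives 3160 nM, and the step of a 990-fold lower number from compound 1 to compound 2 (2.99 log units; beyond the scatter) is the only measured one. Compound 3 `CC(C)(C)c1ccc(S(=O)(=O)Nc2ccc(Cl)cc2-c2nc(N)ncc2O)cc1` is not yet measured; it differs from compound 2 by a group of 8 heavy atoms (4 carbon, 3 nitrogen, 1 oxygen; one six-membered aromatic ring with 2 hetero atoms) in place of a group of 7 heavy atoms (4 carbon, 3 nitrogen; one six-membered aromatic ring with 2 hetero atoms), on an aromatic carbon, sitting on an aromatic carbon of a six-membered aromatic ring of carbon only, ortho to a large group and meta to a chloro group. Within the data shown here, no measured step covers a change of this kind: the one known step exchanged the whole ring attached at this position rather than altering its substituents, so it gives little direct guidance. For compound 3 a modest step of a 3.1-fold higher number from compound 2 to compound 3 (0.49 log units; beyond the scatter) toward a somewhat higher number is expected. Compound 3 is therefore estimated at 10 nM, within a range of 2 nM to 60 nM.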

Compound 3, half-maximal inhibitory concentration: 4 nM
Compound 3: the middle estimate sits 2.5-fold (0.40 log units) above what was measured; the range from low to high includes it.
By their numbers in this assay, from the lowest: compounds 2 and 3 (each within the scatter of the next); then compound 1.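

In this assay, the entering group keeps the six-membered aromatic ring with 2 hetero atoms and adds an oxygen, and the step of a 1.3-fold higher number from compound 2 to compound 3 (0.10 log units; within the scatter) shows that compounds 2 and 3 cannot be told apart. Within the data shown here, the low number at this position is therefore not confined to the single group of compound 2, since a second group with this ring type also gives a large step, a 790-fold lower number from compound 1 to compound 3 (2.90 log units; beyond the scatter). Nothing shown explains why these groups read as they do.

The compounds shown leave open which part of the group in compound 1 goes with its high number, the ring with 1 hetero atom or its other substituent. They also leave open how a methoxy group or a carboxylic acid on the ring with 2 hetero atoms would read.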